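A few compounds are considered here, and "the series" means these few. Any claim that something is new, unique, unknown or untested is made for them only; others in the source may bear on it.

Compound 2, with the structure `CC(C)C(CC(N)=O)c1ccc(-c2ccc3cccc(F)c3c2)[nH]c1=O`, gives the lower of the two numbers recorded so far. In a functional assay on CHO cells for antagonist activity at prostaglandin E2 receptor EP3 subtype (Homo sapiens), read by cAMP accumulation (on this read-out lower numbers stand for stronger inhibition and higher numbers for weaker inhibition), compound 2 gives 53 nM, while compound 1, the structure `CC(C)C(c1ccc(-c2ccc3cccc(F)c3c2)[nH]c1=O)N1CCCCS1(=O)=O`, gives 122 nM in this assay. Among the measured compounds shown here, the only measured step, a 2.3-fold lower number from compound 1 to compound 2 (0.36 log units; beyond the scatter), exchanged a larger ring-bearing group for the carbamoylmethyl chain at the same chain carbon.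

Compound 3, the structure `CC(C)C(/C=C1\CCNC1=O)c1ccc(-c2ccc3cccc(F)c3c2)[nH]c1=O`, is not yet measured. Its change from compound 2 is a group of 7 heavy atoms (5 carbon, 1 nitrogen, 1 oxygen; one five-membered non-aromatic ring with 1 hetero atom) in place of a group of 4 heavy atoms (2 carbon, 1 nitrogen, 1 oxygen; no ring), on a saturated chain carbon bound to an aromatic carbon and a saturated chain carbon. This again places a ring-bearing group at the chain carbon where the step from compound 1 to compound 2 moved the number downward when the ring was removed; the new group, however, keeps one hydrogen-bond donor and one hydrogen-bond acceptor like the group it replaces. For the measured compounds named here, no measured step shows this exact exchange. For compound 3 the expected step is a 1.3-fold higher number from compound 2 to compound 3 (0.12 log units; within the scatter), roughly within the scatter. Compound 3 is therefore estimated at 70 nM in this assay, with a range from 20 nM to 250 nM.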

Compound 3, half-maximal inhibitory concentration: 8.7 nM
Beside the measured number, compound 3's estimate is 8.0-fold (0.91 log units) above it; measured number outside the range, below it.
By their numbers in this assay, from the lowest: compound 3; then compound 2; then compound 1.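

In this assay, among the compounds shown here, at this place, a 6.1-fold lower number from compound 2 to compound 3 (0.78 log units; beyond the scatter) shows that a ring-bearing group can give a lower number than the open carbamoylmethyl chain, whereas the only earlier step had run the other way. Likewise, a 14-fold lower number from compound 1 to compound 3 (1.15 log units; beyond the scatter) shows that two ring-bearing groups on this saturated chain carbon can give very different numbers, so having a ring does not by itself set the result. Nothing measured here gives a reason for either step.

The ring and the extra double bond enter together, so the compounds shown leave open which of them goes with the lower number, and the same ring joined through a saturated two-carbon link would separate them. Also open, on these data alone, is what a methyl group on the ring nitrogen, replacing the amide hydrogen, would do.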